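Trimming Compound 1 to Compound 4

The source may hold more compounds than are shown below. What is called first, only, known or untested is meant among the compounds shown, and "the series" means these compounds.

Going by the values given here, in a functional assay on SW-620 cells (Homo sapiens) for inhibition, read by MTT assay, with a stated time of 72 h (a lower number here means a stronger inhibitor, a higher number a weaker inhibitor), compound 1 `COc1cc(NC(C)CCCNC(=O)NNC(=O)Nc2ccc(Cl)cc2)c2ncccc2c1` gives 48000 nM, the highest of the three numbers so far. Compound 2 `COc1cc(NC(C)CCCNC(=O)NNC(=O)Nc2ccc(C(F)(F)F)cc2)c2ncccc2c1` gives 12000 nM, and compound 3 `COc1cc(NC(C)CCCNC(=O)Nc2cc(C(F)(F)F)cc(C(F)(F)F)c2)c2ncccc2c1` gives 3900 nM. Compound 4 `COc1cc(NC(C)CCCNC(=O)Nc2ccc(Cl)cc2)c2ncccc2c1` is still unmeasured and differs from compound 1 as follows: 4-chlorophenyl in place of ((4-chlorophenyl)carbamoyl)amino on an amide-type nitrogen. Among the compounds with values here, no measured step makes this change. Within the data shown here, the only step available, a 4.0-fold lower number from compound 1 to compound 2 (0.60 log units; beyond the scatter), concerns a different change and serves merely as a gauge of size. Compound 3 also carries an aromatic ring on an amide-type nitrogen, and its 3900 nM lies below the number of compound 1. A modest step to a lower number is therefore expected in this assay, estimated as a 3.4-fold lower number from compound 1 to compound 4 (0.54 log units; beyond the scatter). For compound 4 the estimate is 14000 nM, with an expected range from 4000 nM to 50000 nM.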

Compound 4, half-maximal inhibitory concentration: 28000 nM
The estimate for compound 4 lay 2.0-fold (0.30 log units) below the measured number, and the stated range covers the measured number.
By their numbers in this assay, from the lowest: compound 3; then compound 2; then compounds 4 and 1 (each within the scatter of the next).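

Going by these compounds alone, on this amide-type nitrogen, 4-chlorophenyl in place of ((4-chlorophenyl)carbamoyl)amino gives a 1.7-fold lower number from compound 1 to compound 4 (0.23 log units; within the scatter) in this assay, the first reading of a change at this position. The larger group can therefore be trimmed without the number shifting beyond the scatter. No evidence on hand bears on this result. The compounds shown leave open how a cyclohexyl ring or a methyl on this nitrogen would read, and whether trifluoromethyl in place of chloro would repeat a 4.0-fold lower number from compound 1 to compound 2 (0.60 log units; beyond the scatter) when made on compound 4.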